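Swapping an aromatic amide cap for a small ring

The source may hold more compounds than are shown below. What is called first, only, known or untested is meant among the compounds shown, and "the series" means these compounds.

Of the compounds shown here, two have so far been tested in an in vitro functional assay on HEK293-A cells for antagonist activity at metabotropic glutamate receptor 5 (Rattus norvegicus), read by calcium flux; on this read-out lower numbers stand for stronger inhibition and higher numbers for weaker inhibition. Compound 1 `O=C(Nc1ccc(Cl)c(-c2nc3ccccc3[nH]2)c1)c1ccc(Br)o1` gives 85 nM in this assay. Compound 2 `COc1ccccc1C(=O)Nc1cccc(NC(=O)c2cccc(F)c2)c1` gives 6480 nM in this assay, the higher of the two numbers, and the gap between it and compound 1 lies beyond the usual scatter, so compound 2 is the weaker of the pair. Compound 3 `COc1ccccc1C(=O)Nc1cccc(NC(=O)C2CCC2)c1` differs from compound 2 in one place: cyclobutyl in place of 3-fluorophenyl on a carbonyl carbon. Going by the values given here, no measured pair shows the effect of such a change, so the expectation rests only on the starting point given by compound 2 with its value of 6480 nM. Because compound 2 already gives 6480 nM, compound 3 is expected to move modestly, with a step estimated at a 1.9-fold higher number from compound 2 to compound 3 (0.27 log units; within the scatter), in the direction of weaker inhibition. Compound 3 is therefore estimated to give about 12000 nM, within a range from 3500 nM to 40000 nM.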

Compound 3, half-maximal inhibitory concentration: > 30000 nM
Compound 3 ended at the assay's limit (the forecaster's own chance of this, stated with the estimate: 35%); middle value at least 2.5-fold (0.39 log units) away from the limit.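

The change from 3-fluorophenyl to cyclobutyl on this carbonyl carbon gives an at least 4.6-fold higher number from compound 2 to compound 3 (0.66 log units; beyond the scatter) in this assay, which shows that inhibition depends on the group at this place. Of these two groups, the six-membered aromatic ring gives a readable value, while the four-membered non-aromatic ring does not. Compound 3 sits at a limit of the assay, not at a number, and the true size of the step stays unknown: the limit of > 30000 nM in this assay, at which 1 of the 3 values shown sits.

The change alters ring size, aromatic character and the fluorine all at once, and the compounds shown cannot separate these three differences. As far as these compounds go, it remains open how an unsubstituted phenyl, which would remove only the fluorine, or a cyclohexyl, which would keep the ring size but not the aromatic character, would behave at this carbonyl carbon.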